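Series notes: amine-nitrogen substituent swap, compound 2 to compound 4

The source may report more compounds than this note shows. Statements on the series, on what has been measured and on what is new or still open speak of the compounds shown alone.

Measured so far, in an assay on a protein complex for inhibition of integrin alpha-5/beta-1 (Homo sapiens), read by ELISA; a higher number here means a weaker inhibitor, a lower number a stronger inhibitor:
- compound 1 `COc1ccnc(NC[C@@H]2C[C@@H](OCC(=O)NC[C@H](NC(=O)C3(C)CCCCC3)C(=O)O)CN2C(=O)OCc2ccccc2)c1`: 0.8 nM
- compound 2 `COc1ccnc(NC[C@@H]2C[C@@H](OCC(=O)NC[C@H](NC(=O)C3(C)CCCCC3)C(=O)O)CN2C(=O)CC(C)(C)C)c1`: 0.55 nM
- compound 3 `CC(C)(C)CC(=O)N1C[C@H](OCC(=O)NC[C@H](NC(=O)C2(C)CCCCC2)C(=O)O)C[C@H]1CNc1ccccn1`: 1.4 nM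

Compound 2 has the lowest number of the three; the gap to compound 1, a 1.5-fold lower number from compound 1 to compound 2 (0.16 log units; within the scatter), lies within the scatter, so the two are not separable, while the gap to compound 3, a 2.5-fold higher number from compound 2 to compound 3 (0.41 log units; beyond the scatter), is beyond it and modest.

Compound 4 `COc1ccnc(NC[C@@H]2C[C@@H](OCC(=O)NC[C@H](NS(=O)(=O)c3c(C)cc(C)cc3C)C(=O)O)CN2C(=O)CC(C)(C)C)c1` differs from compound 2 at a single site: (2,4,6-trimethylphenyl)sulfonyl in place of (1-methylcyclohexyl)carbonyl on an amine nitrogen. Neither measured step bears on this site. The step from compound 1 to compound 2 concerns the carbonyl substituent of the core and was within the scatter; the step from compound 2 to compound 3 concerns the aromatic methoxy and was modest. Nothing measured here speaks to the amide-to-sulfonamide exchange on the amine nitrogen, so the direction is open and the range must be wide.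

Compound 4 is expected at 1.5 nM, between 0.3 nM and 8 nM. That estimate means a step of a 2.7-fold higher number from compound 2 to compound 4 (0.44 log units; beyond the scatter) in this assay, treated as a loose expectation given the absence of a comparable measured step.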

Compound 4, half-maximal inhibitory concentration: 0.9 nM
Compound 4: middle estimate off by 1.7-fold (0.22 log units), on the high side, and the stated range covers the measured number.
By their numbers in this assay, from the lowest: compounds 2, 1, 4 and 3 (each within the scatter of the next, the first and the last beyond it).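

In this assay, the first change measured on this amine nitrogen gives a 1.6-fold higher number from compound 2 to compound 4 (0.21 log units; within the scatter), so (2,4,6-trimethylphenyl)sulfonyl and (1-methylcyclohexyl)carbonyl cannot be separated on this pair. The earlier steps shown here covered only the carbonyl substituent of the core and the aromatic methoxy; this one shows that, with the rest of compound 2 unchanged, neither the carbonyl link nor the non-aromatic ring is needed to keep the number within the scatter. The data give no reason for this equivalence.

Still open, going by these compounds, is how an unsubstituted phenylsulfonyl or a small acetyl would read on the same amine nitrogen. Also open, on these data alone, is whether (2,4,6-trimethylphenyl)sulfonyl would give a similar step with the benzyloxy carbonyl of compound 1 or the unsubstituted aromatic ring of compound 3.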